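The source may report more compounds than this note shows. Statements on the series, on what has been measured and on what is new or still open speak of the compounds shown alone.

Compound 1 `COc1ccc(OCCOCCNC2CCCC2)cc1`: 99100 nM
Compound 2 `c1ccc(COc2ccc(OCCOCCNC3CCCC3)cc2)cc1`: 24800 nM
Compound 3 `c1ccc(COc2ccc(OCCOCCOC3CCCC3)cc2)cc1`: not yet measured

In a functional assay on SK-OV-3 cells (Homo sapiens) for inhibition, read by CCK-8 assay, with a stated time of 70 h (a lower number here means a stronger inhibitor, a higher number a weaker inhibitor), compound 2 has the lower number of the two measured compounds at 24800 nM, while compound 1 gives 99100 nM. Compound 3 differs from compound 2 in one place: cyclopentyloxy in place of cyclopentylamino on a saturated chain carbon, two bonds along the chain from an oxygen on a saturated carbon. Within the data shown here, the only measured step, a 4.0-fold lower number from compound 1 to compound 2 (0.60 log units; beyond the scatter), was modest and beyond the scatter, but it concerns phenyl in place of hydrogen on a saturated chain carbon bound to an oxygen on an aromatic ring, not this exchange. Among the measured compounds shown here, no measured pair changes the cyclopentylamino group, so the data give no direct size or direction here. A modest move toward a higher number, similar in size to that one step, is expected as a loose judgement. The expected step is a 2.4-fold higher number from compound 2 to compound 3 (0.38 log units; beyond the scatter). Compound 3 is estimated at 60000 nM, with an expected range of 18000 nM to 180000 nM.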

Compound 3, half-maximal inhibitory concentration: > 100000 nM
Compound 3: only a limit was reported; the forecaster's own chance of this, stated with the estimate: 25%; middle value at least 1.6-fold (0.22 log units) from the limit.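

In this assay, among these compounds, cyclopentyloxy in place of cyclopentylamino gives an at least 4.0-fold higher number from compound 2 to compound 3 (0.60 log units; beyond the scatter), the first measured change at this place, and it shows that this exchange moves toward a weaker inhibitor. Compound 3 has only a limit, not a number: the limit of > 100000 nM in this assay, at which 1 of the 3 values shown sits. The two groups have the same count of heavy atoms and the same five-membered carbon ring, and the leaving group has 1 hydrogen-bond donor where the entering group has 0, but this count alone does not tie the change in the number to any single feature.

The compounds shown leave open whether the nitrogen itself or its hydrogen matters at this place. A methyl(cyclopentyl)amino group, a cyclopentanecarboxamide or a cyclohexylamino group at the same place would help to separate these readings.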